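This account rests on a few compounds, and the source may have more. Where it says the series, first, only, none or still open, it means among the compounds named here.

Measured compounds:
Compound 1 `Cc1nnc(COc2cnn(C(C)(C)C)c(=O)c2Cl)o1` gives in a functional assay on the whole organism for inhibition, with Mythimna separata as the target, with a stated time of 5 days (on this read-out higher numbers stand for an effect only at larger amounts of compound and lower numbers for an effect already at smaller amounts), a value of > 299000 nM, which is a limit of the assay and not a number.
Compound 2 `CC(C)(C)n1ncc(OCc2nnc(-c3ccccc3)o2)c(Cl)c1=O` gives in this assay a value of 12200 nM.

Within the data shown here, compound 2 is the only compound of the pair with a number in this assay; the other entry is a limit, described by the limit of > 299000 nM in this assay, at which 1 of the 2 values shown sits. Compound 3 `Cc1cccc(-c2nnc(COc3cnn(C(C)(C)C)c(=O)c3Cl)o2)c1` differs from compound 2 by methyl in place of hydrogen on an aromatic carbon. Among the measured compounds shown here, the single measured step concerns a different change: an at least 24-fold lower number from compound 1 to compound 2 (1.38 log units; beyond the scatter). That step exchanged a methyl for the phenyl that compound 3 retains; it does not speak to a methyl added onto that phenyl. For the measured compounds named here, no measured step bears directly on the change from compound 2 to compound 3, so in this assay no shift beyond the usual scatter is expected in either direction. Compound 3 is therefore estimated at about 10000 nM, with a range from 3000 nM to 35000 nM. For compound 3 this amounts to an expected step of a 1.2-fold lower number from compound 2 to compound 3 (0.09 log units; within the scatter), a change within the scatter.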

Compound 3, half-maximal effective concentration: 116000 nM
Estimate against measurement, compound 3: 12-fold (1.06 log units) below; measured number outside the range, above it.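

In this assay, the change from phenyl to 3-methylphenyl is not neutral: the single added methyl gives a 9.5-fold higher number from compound 2 to compound 3 (0.98 log units; beyond the scatter), so this place on the phenyl responds to substitution, which the earlier step, an exchange of the whole group, could not show. Against the methyl of compound 1, part of what the phenyl brought survives the added methyl, with an at least 2.5-fold lower number from compound 1 to compound 3 (0.41 log units; beyond the scatter), while compound 2 keeps the lowest number of the three. This last step is only a minimum, and what compound 1 shows is a limit and not a number: the limit of > 299000 nM in this assay, at which 1 of the 3 values shown sits.

From the compounds shown here alone, whether a fluorine or a methoxy group at the same place would raise the number as the methyl does stays open, as does what a methyl would do on another carbon of the phenyl. Why the methyl has this effect cannot be told from these values, since the three compounds give one substituted phenyl and nothing to set beside it.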